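This account rests on a few compounds, and the source may have more. Where it says the series, first, only, none or still open, it means among the compounds named here.

Working notes on the series.

Two compounds have numbers in a functional assay on CHO cells with adenosine receptor A1 (Homo sapiens) as the target, read by cAMP accumulation and immunoassay, with a stated time of 6 min, tested at 0.01 uM (on this read-out higher numbers stand for a weaker effect at the one concentration tested and lower numbers for a stronger effect), so far. Compound 1, `Nc1scc(CN2CCC(c3ccc(Cl)cc3)CC2)c1C(=O)c1ccc(Cl)cc1`, gives 0% in this assay. Compound 2, `Nc1scc(CN2CCN(C3CCCCCC3)CC2)c1C(=O)c1ccc(Cl)cc1`, gives 2.9% in this assay. The two numbers lie within the usual scatter of each other, so nothing separates compound 1 from compound 2 on this read-out; both stand at the weak end of what the assay can report at the one concentration used. Within the data shown here, no step between measured compounds is available to calibrate the series.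

Compound 3, `Nc1scc(CN2CCN(c3cc(Cl)ccc3Cl)CC2)c1C(=O)c1ccc(Cl)cc1`, has not yet been measured. It differs from compound 2 in one place: 2,5-dichlorophenyl in place of cycloheptyl on an amine nitrogen in a ring. With compound 1 and compound 2 both giving numbers close to zero and within scatter of each other, there is no basis in the data for expecting the exchange on the ring nitrogen to move the read-out by more than the scatter in either direction; the step from compound 2 to compound 3 is expected to be a number 0.1 percentage points higher from compound 2 to compound 3 (within the scatter). On that basis compound 3 is estimated at 3% in this assay, with a range from -5% to 15%.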

Compound 3, a percentage reported as activity, at one concentration (the size of the read-out at that concentration, not a potency): 13%
The estimate for compound 3 lay 10 percentage points below the measured number; the measured number falls inside the stated range.
By their numbers in this assay, from the lowest: compounds 1 and 2 (each within the scatter of the next); then compound 3.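

In this assay, 2,5-dichlorophenyl in place of cycloheptyl on the amine nitrogen in a ring gives a number 10.1 percentage points higher from compound 2 to compound 3 (beyond the scatter), a modest step towards a weaker effect at the one concentration tested. Among these compounds, this shows that the read-out responds to the group at this position, which the earlier compounds could not show, since they offered no step between compounds differing in one place. No measurement shown accounts for the size or direction of this step.

The change replaces a non-aromatic seven-membered carbon ring with an aromatic six-membered one and also brings in chlorine, and a single step cannot separate these features. Still open, going by these compounds, is whether a plain phenyl or a cyclohexyl on the same nitrogen would stay with compound 2 or move with compound 3, and whether a 2-chlorophenyl or a 3-chlorophenyl would show that one chlorine alone carries part of the step.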